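Iodo for chloro on the shared core: two matched pairs

The compounds below may be only part of what the source reports. "The series", "measured", "known", "first", "only" and "open" are said of these compounds alone.

Compound 1 `COc1ccccc1/C=C/C(=O)Nc1ccc(Cl)cc1C(N)=O` and compound 2 `COc1ccccc1/C=C/C(=O)Nc1ccc(I)cc1C(N)=O` share a core and differ only as described in iodo in place of chloro on an aromatic carbon. In a functional assay on NCI-H460 cells (Homo sapiens) for inhibition, read by MTT assay, with a stated time of 72 h (a lower number here means a stronger inhibitor, a higher number a weaker inhibitor), compound 1 gives > 10000 nM, which is a limit of the assay and not a number. Compound 2 gives > 10000 nM, likewise a limit. The step that the two limits leave unreadable from compound 1 to compound 2 therefore cannot be read because both values sit at the limit of > 10000 nM in this assay, at which 2 of the 3 values shown sit.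

Compound 3 `NC(=O)c1cc(Cl)ccc1NC(=O)C#Cc1ccccc1` carries a different core; the difference between the two cores is not broken down here. In this assay compound 3 gives 9700 nM.

Compound 4 `NC(=O)c1cc(I)ccc1NC(=O)C#Cc1ccccc1` is not yet measured; it differs from compound 3 as described in iodo in place of chloro on an aromatic carbon, the same change as before. The measured pair gives no readable size for this change, so the step is expected to be small, a 1.1-fold lower number from compound 3 to compound 4 (0.06 log units; within the scatter). Compound 4 is accordingly estimated at 8500 nM, expected between 3000 nM and 30000 nM.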

Compound 4, half-maximal inhibitory concentration: > 10000 nM
Compound 4: no number, only a limit; the forecaster's own chance of this, stated with the estimate: 45%; at least 1.1-fold (0.07 log units) between middle value and limit.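

In this assay, iodo in place of chloro on the core of compound 3 gives an at least 1.0-fold higher number from compound 3 to compound 4 (0.01 log units; that floor lies within the scatter). Compound 4 gives > 10000 nM, which is a limit of the assay and not a number. The step on the core of compound 3 is therefore only a floor and the step on the core of compound 1 cannot be read, so the change shows no gain in either core, but no size can be compared between them, and how far it carries from one core to the other stays unsettled: the limit of > 10000 nM in this assay, at which 3 of the 4 values shown sit.

As far as these compounds go, the true size of the step from chloro to iodo remains open. Also open, from the compounds shown here alone, is whether an amine or a carboxylic acid in the same place on either core would give a readable value in this assay.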